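The source may hold more compounds than are shown below. What is called first, only, known or untested is meant among the compounds shown, and "the series" means these compounds.

The measured compounds:
Compound 1, `C[Se]/C(=N\C(=O)c1cc2ccccc2s1)NC(=O)c1cc2ccccc2s1`; in a functional assay on PC-3 cells (Homo sapiens) for cytotoxicity, read by MTT assay, with a stated time of 72 h (on this read-out lower numbers stand for stronger inhibition of growth and higher numbers for weaker inhibition of growth), compound 1 gives 37200 nM.
Compound 2, `O=C(/N=C(/NC(=O)c1ccno1)[Se]Cc1ccccc1)c1ccno1`; in this assay compound 2 gives 53100 nM.
Compound 3, `C[Se]/C(=N\C(=O)c1cnc2ccccc2c1)NC(=O)c1cnc2ccccc2c1`; in this assay compound 3 gives 2330 nM.

Compound 3 holds the lowest number of the three. Compound 1 stands at a higher number and compound 2 higher still; both gaps to compound 3 lie beyond the usual scatter. Compound 4, `CS/C(=N\C(=O)c1cnc2ccccc2c1)NC(=O)c1cnc2ccccc2c1`, has not yet been measured in this assay. Its change from compound 3 is a group of 2 heavy atoms (1 carbon, 1 sulfur; no ring) in place of a group of 2 heavy atoms (1 carbon, 1 selenium; no ring), on a carbon with a double bond to nitrogen. Among the compounds with values here, no measured pair shows this exchange; the expected step is a 3.4-fold higher number from compound 3 to compound 4 (0.54 log units; beyond the scatter), toward a higher number. Compound 4 is estimated at 8000 nM, within a range from 2500 nM to 30000 nM.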

Compound 4, concentration for 50% growth inhibition: 76300 nM
For compound 4 the middle estimate is 9.5-fold (0.98 log units) below the measured one; the measured number lies above the stated range.
By their numbers in this assay, from the lowest: compound 3; then compounds 1, 2 and 4 (each within the scatter of the next, the first and the last beyond it).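

In this assay, methylsulfanyl in place of the selenium-bearing group, on a carbon with a double bond to nitrogen, gives a 33-fold higher number from compound 3 to compound 4 (1.52 log units; beyond the scatter), a large step beyond the scatter. Within the data shown here, this is the first direct reading at this position, and it shows that exchanging selenium for sulfur alone, with the rest of the molecule unchanged, can move the number this far. Nothing measured here explains the size of this step.

On these data alone, whether the same exchange gives a like step on the core of compound 1 stays open. So does what an ethyl chain or an amine would do at this place.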